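The source may report more compounds than this note shows. Statements on the series, on what has been measured and on what is new or still open speak of the compounds shown alone.

Measured so far:
compound 1 `Cc1cc(=O)c(O)c(C(=O)O)o1`: 27%
compound 2 `O=C(O)c1occc(=O)c1O`: 5%
compound 3 `O=C(O)c1ccc2cccc(O)c2[n+]1[O-]`: 16%

In an assay on isolated protein for inhibition of methionine aminopeptidase 2 (Homo sapiens), read by fluorescence, tested at 200 uM (a lower number here means less inhibition, a higher number more inhibition at the concentration tested (going by the name of the read-out)), compound 1 stands highest of the three; compound 3 lies 16% and compound 2 lies lowest at 5%. Compound 4 `Cc1cc(=O)c(O)c(C(N)=O)o1` differs from compound 1 by amino in place of hydroxy on a carbonyl carbon. For the measured compounds named here, the one measured step, a number 22 percentage points lower from compound 1 to compound 2 (beyond the scatter), concerns the methyl on an aromatic carbon, not the carbonyl carbon, so no measured step bears directly on this change. With no comparison to rest on, the account expects a shift from compound 1 to compound 4 of a number 7 percentage points lower from compound 1 to compound 4 (within the scatter), a small downward lean that stays within the scatter. Compound 4 is therefore estimated at 20%, with a range from 5% to 40%.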

Compound 4, a percentage reported as inhibition, at one concentration (the size of the read-out at that concentration, not a potency): 35%
Beside the measured number, compound 4's estimate is 15 percentage points below it; low and high end bracket the measured number.
By their numbers in this assay, from the lowest: compound 2; then compound 3; then compounds 1 and 4 (each within the scatter of the next).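

In this assay, for the compounds shown here, the change from carboxy to carbamoyl at the carbonyl carbon gives a number 8 percentage points higher from compound 1 to compound 4 (within the scatter) and is the first measured step at this position. On the core of compound 1, the hydroxy of the carboxy group can therefore be replaced by amino without a change beyond the scatter. Nothing available explains this result.

As far as these compounds go, whether the same replacement holds on compound 2 or compound 3 remains open. The compounds shown also leave open what a methyl ester or a nitrile would give at this carbon.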